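The source may report more compounds than this note shows. Statements on the series, on what has been measured and on what is new or still open speak of the compounds shown alone.

Of the compounds shown here, two have been measured in an assay on HEK293 cells for displacement of a labelled ligand from B1 bradykinin receptor (Homo sapiens), read by scintillation counting; a higher number here means a weaker inhibitor, a lower number a stronger inhibitor. Among the measured compounds shown here, compound 2, `CN(Cc1ccc(C2=NCCN2)cc1)C(=O)COCCN(C)S(=O)(=O)c1c(Cl)cccc1Cl`, gives 4.2 nM, the lower of the two numbers so far, and compound 1, `COc1cc(C)c(S(=O)(=O)N(C)CCOCC(=O)N2CCC(C(C)(C)CN(C)C)CC2)c(C)c1`, gives 10 nM, a gap that lies beyond the usual scatter. Compound 3, `CN(Cc1ccc(C2=NCCN2)cc1)C(=O)COCCN(C)S(=O)(=O)c1c(F)cccc1F`, has not yet been measured; it differs from compound 2 by 2,6-difluorophenyl in place of 2,6-dichlorophenyl on a sulfonyl sulfur. For the measured compounds named here, no measured pair shows this change, so its effect can only be estimated; a modest loss is expected, a 2.4-fold higher number from compound 2 to compound 3 (0.38 log units; beyond the scatter). Compound 3 is therefore expected to give 10 nM in this assay, with a range from 3 nM to 40 nM.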

Compound 3, inhibition constant: 142 nM
The estimate for compound 3 lay 14-fold (1.15 log units) below the measured number; the measured number lies above the stated range.
By their numbers in this assay, from the lowest: compound 2; then compound 1; then compound 3.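

In this assay, replacing 2,6-dichlorophenyl with 2,6-difluorophenyl on a sulfonyl sulfur gives a 34-fold higher number from compound 2 to compound 3 (1.53 log units; beyond the scatter), even though the counts of heavy atoms, hydrogen-bond donors and hydrogen-bond acceptors stay the same. Among the compounds shown here, this first matched step shows that the number at this position depends strongly on which halogen the ring carries, something the earlier compounds, which differ in more than one place, could not show. No measurement here explains the loss. The compounds shown leave open whether bromine or methyl in place of the chlorine atoms would keep the number low.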